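Methoxy in place of hydrogen on compound 2

The source may hold more compounds than are shown below. What is called first, only, known or untested is meant among the compounds shown, and "the series" means these compounds.

In a functional assay on K562 cells (Homo sapiens) for cytotoxicity, read by MTT assay, with a stated time of 24 h (a higher number here means a weaker inhibitor, a lower number a stronger inhibitor), compound 2 (`COc1cc(/C=C2\CN(C)C/C(=C\c3cccc([N+](=O)[O-])c3)C2=O)cc(OC)c1`) gives 4420 nM as the lower of two numbers, and compound 1 (`COc1cc(/C=C2\CN(C)C/C(=C\c3ccc(Cl)cc3Cl)C2=O)cc(OC)c1`) gives 11900 nM in comparison. Compound 3 (`COc1cc(/C=C2\CN(C)C/C(=C\c3cccc([N+](=O)[O-])c3)C2=O)cc(OC)c1OC`) has methoxy in place of hydrogen on an aromatic carbon, ortho to two methoxy groups (methoxy in place of hydrogen on an aromatic carbon). Going by the values given here, the only measured step, a 2.7-fold lower number from compound 1 to compound 2 (0.43 log units; beyond the scatter) with 3-nitrophenyl in place of 2,4-dichlorophenyl, is modest and concerns another group, so in this assay no step beyond the scatter is expected. Going by these compounds, the expected size is a 1.1-fold lower number from compound 2 to compound 3 (0.04 log units; within the scatter) and its direction stays open. For compound 3 the estimated value is 4000 nM (range 1500 nM to 10000 nM).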

Compound 3, half-maximal inhibitory concentration: 4200 nM
Estimate against measurement, compound 3: 1.1-fold (0.02 log units) below, and the stated range covers the measured number.
By their numbers in this assay, from the lowest: compounds 3 and 2 (each within the scatter of the next); then compound 1.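

In this assay, methoxy in place of hydrogen on the aromatic carbon ortho to two methoxy groups leaves compound 2 and compound 3 level (a 1.1-fold lower number from compound 2 to compound 3 (0.02 log units; within the scatter)). This position therefore takes the added methoxy with no step beyond the scatter, at least with 3-nitrophenyl on the other side of the core. Nothing measured here speaks to why the number holds.

Open, going by these compounds, is whether a hydroxy group or an amine at this position would hold the number as well. Also open, on these data alone, is whether the added methoxy behaves the same alongside the 2,4-dichlorophenyl of compound 1.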